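This account rests on a few compounds, and the source may have more. Where it says the series, first, only, none or still open, it means among the compounds named here.

Three small anilide-type compounds share one core and differ in a single group on the aromatic ring. They were tested in a functional assay on A549 cells (Homo sapiens) for antiproliferative activity, read by MTT assay, with a stated time of 72 h; on this read-out lower numbers stand for stronger inhibition and higher numbers for weaker inhibition. Compound 1 (`Cc1ccccc1NC(=O)C(Cl)Cl`) gave no number, and its result reads "not determined" (no result reported). Compound 2 (`O=C(Nc1ccccc1F)C(Cl)Cl`) gives 87500 nM, and compound 3 (`O=C(Nc1ccccc1Cl)C(Cl)Cl`) gives 50200 nM. Among the compounds with values here, compound 2 therefore has only one numerical neighbour, and the two values lie within the scatter of each other.

The next compound to consider is compound 4 (`O=C(Nc1ccccc1Br)C(Cl)Cl`), which has not yet been measured in this assay. It carries bromo in place of fluoro on an aromatic carbon.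

Within the data shown here, only one measured step bears on this change, also a swap of one halogen for another on an aromatic carbon. That step is a 1.7-fold lower number from compound 2 to compound 3 (0.24 log units; within the scatter), so it gives no firm sign of a real trend. Among the measured compounds shown here, with this single small step as the only guide, no shift beyond the scatter is expected for the bromo compound. The expected step is a 1.8-fold lower number from compound 2 to compound 4 (0.24 log units; within the scatter), an estimate that stays within the scatter. For compound 4 the estimated value is 50000 nM. The expected range for this estimate runs from 22000 nM to 100000 nM.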

Compound 4, half-maximal inhibitory concentration: 37000 nM
Compound 4: middle estimate off by 1.4-fold (0.13 log units), on the high side, and the stated range covers the measured number.
By their numbers in this assay, from the lowest: compounds 4, 3 and 2 (each within the scatter of the next, the first and the last beyond it).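

In this assay, within the data shown here, bromo in place of fluoro on an aromatic carbon gives a 2.4-fold lower number from compound 2 to compound 4 (0.37 log units; beyond the scatter) and is thus the first step in this set to clear the scatter, though only modestly. Bromo in place of chloro gives a 1.4-fold lower number from compound 3 to compound 4 (0.13 log units; within the scatter) and so does not separate these two halogens, and chloro could not be separated from fluoro either; only the fluoro and bromo compounds stand apart at this position. Nothing available here explains why this halogen swap shifts the number.

The compounds shown leave open whether iodo at the same place would continue the step, and whether a group that is not a halogen, such as methoxy, a nitrile or an amine, would give a similar number. From the compounds shown here alone, compound 1, with its methyl group, gives "not determined" (no result reported) and so offers no comparison with the halogens, and it also remains open how bromo would fare on another carbon of the ring.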